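This account rests on a few compounds, and the source may have more. Where it says the series, first, only, none or still open, it means among the compounds named here.

Measured compounds:
Compound 1 `CNC(=O)c1cc(Oc2ccc(NC(=O)c3cc4cccnc4n(-c4ccc(F)c(Cl)c4)c3=O)cc2)ccn1` — 1810 nM
Compound 2 `CCNC(=O)c1cc(Oc2ccc(NC(=O)c3cc4cccnc4n(-c4ccc(Cl)cc4)c3=O)cc2)ccn1` — 330 nM
Compound 3 `CCNC(=O)c1cc(Oc2ccc(NC(=O)c3cc4cccnc4n(-c4ccc(OC)cc4)c3=O)cc2)ccn1` — 3350 nM

In a functional assay on HT-29 cells (Homo sapiens) for antiproliferative activity, read by MTT assay, with a stated time of 72 h (a higher number here means a weaker inhibitor, a lower number a stronger inhibitor), compound 3 gives the highest number of the three, close to compound 1 and far from compound 2. Compound 4 `CCNC(=O)c1cc(Oc2ccc(NC(=O)c3cc4cccnc4n(-c4ccc(F)c(Cl)c4)c3=O)cc2)ccn1` differs from compound 3 by 3-chloro-4-fluorophenyl in place of 4-methoxyphenyl on an aromatic nitrogen. Going by the values given here, one measured step bears on this: a 10-fold higher number from compound 2 to compound 3 (1.01 log units; beyond the scatter), and the move to compound 4 reverses that methoxy-for-chloro exchange while also adding a fluorine. Compound 1, which carries the same 3-chloro-4-fluorophenyl group but a methyl amide rather than an ethyl amide, gives 1810 nM, which tempers the expectation. Compound 4 is therefore expected to show a drop of a 5.6-fold lower number from compound 3 to compound 4 (0.75 log units; beyond the scatter), landing at 600 nM, within 200 nM to 2000 nM.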

Compound 4, half-maximal inhibitory concentration: 2600 nM
The estimate for compound 4 lay 4.3-fold (0.64 log units) below the measured number; the whole stated range lies below it.
By their numbers in this assay, from the lowest: compound 2; then compounds 1, 4 and 3 (each within the scatter of the next).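

In this assay the exchange of 4-methoxyphenyl for 3-chloro-4-fluorophenyl on the aromatic nitrogen gives a 1.3-fold lower number from compound 3 to compound 4 (0.11 log units; within the scatter) and so does not separate these two groups at this position. Among the ethyl amides, 4-chlorophenyl alone stands apart, with a 7.9-fold higher number from compound 2 to compound 4 (0.90 log units; beyond the scatter) on the change to 3-chloro-4-fluorophenyl. With that group in place, methyl in place of hydrogen on the amide chain gives a 1.4-fold higher number from compound 1 to compound 4 (0.16 log units; within the scatter) and does not separate the two amides. No measurement at hand explains these differences. From the compounds shown here alone, whether 4-fluorophenyl or 3-chlorophenyl on that nitrogen would group with compound 2 or with compound 4 stays open.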